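Changing the sulfonamide substituent on a fluorinated chain

A few compounds are considered here, and "the series" means these few. Any claim that something is new, unique, unknown or untested is made for them only; others in the source may bear on it.

- compound 1 `CCCCCCCCNc1ccc(C(=O)O)cc1S(N)(=O)=O`: 0.3 h
- compound 2 `CCCCCCNc1ccc(C(=O)O)cc1S(=O)(=O)NC`: 0.483 h
- compound 3 `CNS(=O)(=O)c1cc(C(=O)O)ccc1NCCCCCCCC(F)(F)F`: > 1 h

All three values come from an ADME assay on microsomes from liver (Mus musculus) for metabolic stability, tested at 5 uM; a higher number here means that the compound lasts longer, a lower number that the compound disappears faster. Compound 3 stands at > 1 h, which is a limit of the assay and not a number. Its true half-life is therefore not known, and any step taken from it starts from an open end.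

The next compound is compound 4 `O=C(O)c1ccc(NCCCCCCCC(F)(F)F)c(S(=O)(=O)NC2CCOCC2)c1`, and the change is oxan-4-yl in place of methyl on a sulfonamide nitrogen. In words, oxan-4-yl takes the place of methyl on a sulfonamide nitrogen, while the rest of compound 3 stays as it is.

Within the data shown here, the one measured step is an at least 2.0-fold higher number from compound 2 to compound 3 (0.31 log units; beyond the scatter). That step lies on the saturated chain, which compound 4 keeps unchanged from compound 3, so it says little about the new group. Among the measured compounds shown here, no measured step changes the sulfonamide nitrogen alone.

For the measured compounds named here, with no direct precedent, the expectation in this assay is for no change beyond the scatter, in either direction, and the uncertainty is wide. As an estimate, this reads a step that the limit leaves unreadable from compound 3 to compound 4. For compound 4 the estimated half-life is 1.2 h, with an expected range from 0.5 h to 3 h.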

Compound 4, half-life: > 1 h
Compound 4 ended at the assay's limit (the forecaster's own chance of this, stated with the estimate: 45%); the middle value lies beyond the limit too.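

In this assay, no step can be read from compound 3 to compound 4, because both values are limits of the assay and not numbers: the limit of > 1 h in this assay, at which 2 of the 4 values shown sit.

The compounds shown leave open how far the half-lives of compound 3 and compound 4 lie past that limit, and whether oxan-4-yl in place of methyl on a sulfonamide nitrogen changes the half-life at all.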